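A few compounds are considered here, and "the series" means these few. Any claim that something is new, unique, unknown or untested is made for them only; others in the source may bear on it.

Compound 2, with the structure `C=C1CC[C@H]2[C@](C)(CO)CCC[C@]2(C)[C@H]1C[C@]12O[C@H]1[C@@H](O)C(CO)=CC2=O`, carries the shared core with hydrogen on the double-bonded ring carbon where compound 1, `C=C1CC[C@H]2[C@](C)(CO)CCC[C@]2(C)[C@H]1C[C@]12O[C@H]1[C@@H](O)C(CO)=C(Cl)C2=O`, bears chloro. In a functional assay on A549 cells (Homo sapiens) for inhibition, read by MTT assay, with a stated time of 72 h (on this read-out higher numbers stand for weaker inhibition and lower numbers for stronger inhibition), compound 1 gives 8000 nM, and in the same measurement compound 2 gives 39800 nM, the highest of the two numbers; the step of a 5.0-fold higher number from compound 1 to compound 2 (0.70 log units; beyond the scatter) separates them. Compound 3, `C=C1CC[C@H]2[C@](C)(CO)CCC[C@]2(C)[C@H]1C[C@@]12O[C@@H]1[C@@H](O)C(CO)=CC2=O`, keeps every atom and bond of compound 2 and differs from it only as drawn: the two compounds have the same atoms and bonds and differ only in configuration as drawn: 2 of 7 stereo elements differ; a stereocentre at a saturated ring carbon is drawn S in compound 2 and R in compound 3; a stereocentre at a saturated ring carbon is drawn S in compound 2 and R in compound 3. Among the measured compounds shown here, no measured pair in this set shows what such a change of configuration at two ring carbons does in this assay; the only measured step, a 5.0-fold higher number from compound 1 to compound 2 (0.70 log units; beyond the scatter), concerns the exchange of chloro for hydrogen and does not bear on a reversal of stereocentres. With nothing to weigh, the account can only expect the number for compound 3 to stay near that of compound 2, and the step of a 1.0-fold higher number from compound 2 to compound 3 (0.00 log units; within the scatter) is therefore estimated to be small, though a wide range must be allowed in either direction. Compound 3 is expected to give about 40000 nM, somewhere between 12000 nM and 130000 nM.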

Compound 3, half-maximal inhibitory concentration: 41500 nM
Compound 3: the middle estimate sits 1.0-fold (0.02 log units) below what was measured, and the stated range covers the measured number.
By their numbers in this assay, from the lowest: compound 1; then compounds 2 and 3 (each within the scatter of the next).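

In this assay, the reversal of the two stereocentres at saturated ring carbons comes to a 1.0-fold higher number from compound 2 to compound 3 (0.02 log units; within the scatter), so this read-out does not separate the two drawn configurations of the hydrogen-bearing compounds. This step can be tied to configuration and nothing else because of one fact: the fact that compounds 2 and 3 differ only in the configuration as drawn. Among the compounds shown here, the exchange of chloro for hydrogen on the double-bonded ring carbon, a 5.0-fold higher number from compound 1 to compound 2 (0.70 log units; beyond the scatter), therefore remains the only step in this set beyond the scatter, while the first measured change of configuration does not go beyond it.

The two stereocentres are reversed together here, so the compounds shown leave open what either reversal does alone, and whether the same configurations would also stand within the scatter of each other with chloro on the double-bonded ring carbon. They also leave open how bromo, an amine or a methyl group would read on that carbon in this assay, and what a carboxylic acid in place of a hydroxymethyl group would do.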